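A second fluoro step, now on a pyridin-4-yl group

This account rests on a few compounds, and the source may have more. Where it says the series, first, only, none or still open, it means among the compounds named here.

Measured compounds:
compound 1, `O=C(O)Cc1sc(C(c2ccc(F)cc2)c2ccc(F)cc2)nc1-c1cccc(F)c1`, 1.4 nM
compound 2, `O=C(O)Cc1sc(C(c2ccc(F)cc2)c2ccc(F)cc2)nc1-c1cc(F)cc(F)c1`, 35 nM
compound 3, `O=C(O)Cc1sc(C(c2ccc(F)cc2)c2ccc(F)cc2)nc1-c1ccncc1`, 5.3 nM

All three numbers come from an in vitro assay on HEK385-7 cells for displacement of a labelled ligand from prostaglandin D2 receptor 2 (Homo sapiens); a lower number here means a stronger inhibitor, a higher number a weaker inhibitor. Compound 4, `O=C(O)Cc1sc(C(c2ccc(F)cc2)c2ccc(F)cc2)nc1-c1ccnc(F)c1`, has not been measured in this assay. It differs from compound 3 by fluoro in place of hydrogen on an aromatic carbon. The same change separates compound 1 from compound 2, (fluoro in place of hydrogen on an aromatic carbon), and there it made a 25-fold higher number from compound 1 to compound 2 (1.40 log units; beyond the scatter). The two cores differ by pyridin-4-yl in place of 3-fluorophenyl on an aromatic carbon, a step of a 3.8-fold higher number from compound 1 to compound 3 (0.58 log units; beyond the scatter). The places differ: in compound 1 the fluoro enters on a ring of carbon only, meta to a fluoro group; in compound 3 it enters on a ring with 1 nitrogen, next to the ring nitrogen. It is therefore the same kind of change, not the same. Compound 4 is expected to give a higher number than compound 3, a 5.7-fold higher number from compound 3 to compound 4 (0.75 log units; beyond the scatter), smaller than the earlier step, since that earlier step a 25-fold higher number from compound 1 to compound 2 (1.40 log units; beyond the scatter) sat on a different ring. Compound 4 is estimated at 30 nM, between 8 nM and 120 nM.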

Compound 4, half-maximal inhibitory concentration: 0.48 nM
Beside the measured number, compound 4's estimate is 63-fold (1.80 log units) above it, outside the stated range (below it).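

In this assay, the same fluoro change did not carry over from one core to the other, and its direction reversed: the same change on two cores in this assay, a 25-fold higher number (1.40 log units; beyond the scatter) from compound 1 to compound 2 and an 11-fold lower number (1.04 log units; beyond the scatter) from compound 3 to compound 4, 280-fold (2.44 log units) apart, beyond the scatter of two such steps

On the pyridin-4-yl core the step reads an 11-fold lower number from compound 3 to compound 4 (1.04 log units; beyond the scatter), and the 2-fluoropyridin-4-yl group also compares favourably with both fluorophenyl groups, with a 73-fold lower number from compound 2 to compound 4 (1.86 log units; beyond the scatter) and a 2.9-fold lower number from compound 1 to compound 4 (0.46 log units; beyond the scatter). This shows that the step measured on one core did not predict the step on the other, but the fluoro also enters at a different place on each ring, and these two pairs do not separate the ring from the place.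

The compounds shown leave open whether chloro, methyl or an amine in place of that fluoro would give a similar step.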